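The compounds below may be only part of what the source reports. "The series", "measured", "known", "first", "only" and "open" are said of these compounds alone.

Compound 1 `CC1=CC[C@H](C(C)(C)N=C=S)CC1`; compound 2 `CC1=CC[C@H](C(C)(C)NC(=S)N/N=C/c2ccccc2)CC1`; compound 3 `CC1=CC[C@H](C(C)(C)NC(=S)N/N=C/c2ccccc2O)CC1`.

In a functional assay on 786-0 cells (Homo sapiens) for inhibition, read by sulforhodamine B assay, with a stated time of 48 h (on this read-out lower numbers stand for stronger inhibition of growth and higher numbers for weaker inhibition of growth), compound 1 gives only a limit, > 100000 nM. Compound 2 gives 9900 nM, and compound 3 gives 4600 nM, the lowest number among the two measured values, with the step of a 2.2-fold lower number from compound 2 to compound 3 (0.33 log units; beyond the scatter) separating them. Compound 4 `CC1=CC[C@H](C(C)(C)NC(=S)N/N=C/c2ccc(Cl)cc2)CC1` differs from compound 3 by 4-chlorophenyl in place of 2-hydroxyphenyl on a carbon with a double bond to nitrogen. Within the data shown here, the one measured step, a 2.2-fold lower number from compound 2 to compound 3 (0.33 log units; beyond the scatter), bears on it only in part: it shows that removing the hydroxy group would be expected to move the number back toward that of compound 2, while the effect of the chlorine has no measured counterpart. For compound 4 the expected step is therefore a modest rise, a 1.5-fold higher number from compound 3 to compound 4 (0.18 log units; within the scatter), giving an estimate of 7000 nM with a range from 2500 nM to 20000 nM.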

Compound 4, concentration for 50% growth inhibition: 74900 nM
Compound 4: the middle estimate sits 11-fold (1.03 log units) below what was measured; the measured number lies above the stated range.
By their numbers in this assay, from the lowest: compound 3; then compound 2; then compound 4. At a limit, above all of these: compound 1.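

At the aromatic ring on the carbon with a double bond to nitrogen, the change proves large: in this assay the step is a 16-fold higher number from compound 3 to compound 4 (1.21 log units; beyond the scatter). Chloro in place of hydrogen also raises the number, with a 7.6-fold higher number from compound 2 to compound 4 (0.88 log units; beyond the scatter), so this ring can move the read-out either way, down with hydroxy and up with chloro. Nothing measured here gives a reason for the rise. 4-Chlorophenyl and 2-hydroxyphenyl differ in both group and place, and it stays open which of the two matters. Also open, going by these compounds, is how 2-chlorophenyl or an amine on this ring would read.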